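A few compounds are considered here, and "the series" means these few. Any claim that something is new, unique, unknown or untested is made for them only; others in the source may bear on it.

Measured in a functional assay (plasma) with Oryctolagus cuniculus as the target; on this read-out lower numbers stand for stronger inhibition and higher numbers for weaker inhibition:
- Compound 1 `Cc1nc2cnccc2n1CC1CCN(C(=O)CC(C)c2ccccc2)CC1`: 12 nM
- Compound 2 `Cc1nc2cnccc2n1CC1CCN(C(=O)CCc2ccccc2)CC1`: 60 nM
- Compound 3 `Cc1nc2cnccc2n1CC1CCN(C(=O)N[C@H](C)c2ccccc2)CC1`: 13 nM

Compound 3 gives 13 nM in this assay. The series shows a 1.1-fold higher number from compound 1 to compound 3 (0.03 log units; within the scatter), so those two cannot be told apart, and it also shows a 4.6-fold lower number from compound 2 to compound 3 (0.66 log units; beyond the scatter).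

The next compound, compound 4 `Cc1nc2cnccc2n1CC1CCN(C(=O)N[C@@H](C)c2ccccc2)CC1`, changes only configuration: the two compounds have the same atoms and bonds and differ only in configuration as drawn: 1 of 1 stereo elements differ; a stereocentre at a saturated chain carbon is drawn R in compound 3 and S in compound 4. A stereocentre at a saturated chain carbon is drawn R in compound 3 and S in compound 4.

Going by the values given here, no measured step inverts a stereocentre, so none gives the size directly. The closest evidence is a 5.0-fold higher number from compound 1 to compound 2 (0.70 log units; beyond the scatter), where hydrogen replaces methyl on a saturated chain carbon. Among the compounds with values here, this shows that the read-out can respond to a change at a branching carbon, although that carbon lies in a different chain from the one in compound 3. A modest step towards a higher number is therefore expected, of similar size or smaller, and a step within the scatter remains possible.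

The step expected is a 2.3-fold higher number from compound 3 to compound 4 (0.36 log units; beyond the scatter). The estimate for compound 4 is 30 nM, with an expected range from 7 nM to 130 nM.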

Compound 4, half-maximal inhibitory concentration: 41 nM
Beside the measured number, compound 4's estimate is 1.4-fold (0.14 log units) below it, and the stated range covers the measured number.
By their numbers in this assay, from the lowest: compounds 1 and 3 (each within the scatter of the next); then compounds 4 and 2 (each within the scatter of the next).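

In this assay, the configuration at the saturated chain carbon of the (1-phenylethyl)amino group matters in its own right, with a 3.2-fold higher number from compound 3 to compound 4 (0.50 log units; beyond the scatter), and this step can be assigned to that single stereocentre because nothing else changes: the fact that compounds 3 and 4 differ only in the configuration as drawn. The earlier agreement between the (1-phenylethyl)amino and 2-phenylpropyl groups therefore holds only for the form drawn R, since the form drawn S gives a 3.4-fold higher number from compound 1 to compound 4 (0.53 log units; beyond the scatter). The same form also gives a 1.5-fold lower number from compound 2 to compound 4 (0.17 log units; within the scatter), so those two compounds cannot be told apart, and the methyl group on this chain carbon, when drawn S, offers no measurable separation from the unbranched phenethyl group.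

On these data alone, compound 1 has no configuration drawn at its branching carbon, so it remains open whether the 2-phenylpropyl chain responds to inversion as the (1-phenylethyl)amino group does. Also open, as far as these compounds go, is how far the difference between the R and S forms would persist with an ethyl group in place of that methyl, or with a fluorine on the phenyl ring.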